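This account rests on a few compounds, and the source may have more. Where it says the series, first, only, none or still open, it means among the compounds named here.

Of the compounds shown here, three have been tested in a functional assay on KB-C2 cells (Homo sapiens) for cytotoxicity, read by MTT assay, with a stated time of 68 h; a higher number here means a weaker inhibitor, a lower number a stronger inhibitor. Compound 1 `CC1=C(CC[C@@H]2[C@@]3(C)CC[C@@H](O)C(C)(C)O[C@@H]3CC[C@]2(C)O)[C@](C)(C/C=C/C(C)(C)O)[C@H](O)CC1` returns only a limit of the assay, > 50000 nM. Compound 2 `CC1=CCC2C(CC[C@@]2(C)O)C(C)(C)C1CC[C@@H]1[C@@]2(C)CC[C@@H](O)C(C)(C)O[C@@H]2CC[C@]1(C)O` likewise returns only a limit, > 50000 nM, so its place among the numbers shown is a limit alone. Compound 3 `CC1(C)O[C@@H]2CC[C@](C)(O)[C@H](CCC3C(C=O)=CCC4C(CC[C@@]4(C)O)C3(C)C)[C@@]2(C)CCC1=O` also gives only a limit, > 50000 nM. All three share (the limit of > 50000 nM in this assay, at which 3 of the 3 values shown sit). Compound 4 `CC1(C)C(CC[C@@H]2[C@@]3(C)CC[C@@H](O)C(C)(C)O[C@@H]3CC[C@]2(C)O)C(C=O)=CCC2C1CC[C@@]2(C)O` differs from compound 2 by formyl in place of methyl on a double-bonded ring carbon. Compound 3 already carries a formyl on a double-bonded ring carbon, and its result in this assay is only a limit, > 50000 nM, which gives no ground to expect a gain. The expected step is a step that the limit leaves unreadable from compound 2 to compound 4, none beyond the scatter. Compound 4 is therefore estimated at 80000 nM, with a range from 30000 nM to 300000 nM.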

Compound 4, half-maximal inhibitory concentration: > 50000 nM
Compound 4 ended at the assay's limit; the forecaster's own chance of this, stated with the estimate: 85%; the middle value lies beyond the limit too.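

Compound 2 and compound 4 both stop at a limit of the assay, so no step can be read between them. The compounds shown leave open whether any change to the shared core gives a measurable value in this assay.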